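Dichloro Substitution Across Two Benzyl Regioisomers

The compounds below may be only part of what the source reports. "The series", "measured", "known", "first", "only" and "open" are said of these compounds alone.

Compound 1 `ClCc1ccccc1Cn1cnc2c(Cl)nc(Cl)nc21` and compound 2 `ClCc1ccccc1Cn1cnc2c(Cl)ncnc21` share one core. In a functional assay on SN12C cells (Homo sapiens) for cytotoxicity, read by sulforhodamine B assay, with a stated time of 48 h (on this read-out lower numbers stand for stronger inhibition of growth and higher numbers for weaker inhibition of growth), compound 1 gives 2040 nM and compound 2 gives 8710 nM. The step of a 4.3-fold lower number from compound 2 to compound 1 (0.63 log units; beyond the scatter) corresponds to chloro in place of hydrogen on an aromatic carbon. Compound 3 `ClCc1cccc(Cn2cnc3ncnc(Cl)c32)c1` has the same atoms as compound 2 joined differently; the difference between the two cores is not broken down here. In this assay compound 3 gives 20400 nM, the highest number of the three. Compound 4 `ClCc1cccc(Cn2cnc3nc(Cl)nc(Cl)c32)c1` differs from compound 3 by chloro in place of hydrogen on an aromatic carbon, the same change as made from compound 2 to compound 1; it occurs in two pairs within this set. Among the measured compounds shown here, the expected step of a 3.7-fold lower number from compound 3 to compound 4 (0.57 log units; beyond the scatter) is taken to follow the earlier one, because the measured step of a 4.3-fold lower number from compound 2 to compound 1 (0.63 log units; beyond the scatter) is the only guide available. Compound 4 is therefore estimated at 5500 nM, expected to fall between 2500 nM and 12000 nM.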

Compound 4, concentration for total growth inhibition: 2750 nM
For compound 4 the middle estimate is 2.0-fold (0.30 log units) above the measured one, and the stated range covers the measured number.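

Chloro in place of hydrogen on an aromatic carbon, between two ring nitrogen atoms, gives a 7.4-fold lower number from compound 3 to compound 4 (0.87 log units; beyond the scatter) in this assay, and the step on the second core matches the one on the first: the same change on two cores in this assay, a 4.3-fold lower number (0.63 log units; beyond the scatter) from compound 2 to compound 1 and a 7.4-fold lower number (0.87 log units; beyond the scatter) from compound 3 to compound 4, 1.7-fold (0.24 log units) apart, within the scatter of two such steps

Across these two cores, the change therefore carries over in direction and in size. Among the compounds shown here, this rests on only two pairs, and it does not show that the change would carry to any other core, or why the number falls.

Open, from the compounds shown here alone, is whether an amine or a methoxy group on the same aromatic carbon would lower the number as chloro does. Going by these compounds, all four compounds carry the chloromethyl group, so what a hydroxymethyl group there would give also remains open.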